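Benzyl for sec-butyl: tolerance on human liver cells

The source may hold more compounds than are shown below. What is called first, only, known or untested is meant among the compounds shown, and "the series" means these compounds.

Compound 1 `CCC[C@H](NC(=O)[C@@H]1C[C@@H]2CN1C(=O)[C@H](C(C)(C)C)NC(=O)OCCCCCCc1cccc3c1CN(C3)C(=O)O2)C(=O)C(=O)CC1CC1` in an ADME assay on Huh-7 cells (Homo sapiens) for cytotoxicity (a lower number here means that less compound is tolerated, a higher number that more compound is tolerated), gives > 50000 nM, which is a limit of the assay and not a number. Compound 2 `CCC[C@H](NC(=O)[C@@H]1C[C@@H]2CN1C(=O)[C@H](C(C)(C)C)NC(=O)OCCCCCCc1cccc3c1CN(C3)C(=O)O2)C(=O)C(=O)NC1CCC1` in this assay gives > 50000 nM, again a limit. Compound 3 `CCC[C@H](NC(=O)[C@@H]1C[C@@H]2CN1C(=O)[C@H](C(C)(C)C)NC(=O)OCCCCCCc1cccc3c1CN(C3)C(=O)O2)C(=O)C(=O)NC(C)CC` in this assay gives > 50000 nM, also a limit.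

Compound 3 therefore stands where all three measured compounds stand: at the limit of > 50000 nM in this assay, at which 3 of the 3 values shown sit. The steps among them, a step that the two limits leave unreadable from compound 1 to compound 2, a step that the two limits leave unreadable from compound 1 to compound 3 and a step that the two limits leave unreadable from compound 2 to compound 3, cannot be sized, since both ends of each are limits.

Compound 4 `CCC[C@H](NC(=O)[C@@H]1C[C@@H]2CN1C(=O)[C@H](C(C)(C)C)NC(=O)OCCCCCCc1cccc3c1CN(C3)C(=O)O2)C(=O)C(=O)NCc1ccccc1` carries the change (benzyl in place of sec-butyl on an amide-type nitrogen). Among the measured compounds shown here, the steps that bear on it all concern the same amide-type nitrogen and all end at the limit, so they give no direction and no size, only the observation that three different groups there left the compounds tolerated up to the limit. For compound 4 the expectation is therefore no readable step in this assay, the estimated step being a step that the limit leaves unreadable from compound 3 to compound 4. The estimated value for compound 4 is 60000 nM, within 30000 nM to 150000 nM.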

Compound 4, half-maximal cytotoxic concentration: > 50000 nM
Compound 4 gave a limit, no number; the forecaster's own chance of this, stated with the estimate: 85%; the middle value does not contradict the limit.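

Compound 4 in this assay also ends at a limit, not a number, so its steps from compound 1, compound 2 and compound 3 cannot be read, and all four compounds stand together: the limit of > 50000 nM in this assay, at which 4 of the 4 values shown sit.

Left open is how much of each compound the cells tolerate, and whether the four differ at all.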